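The source may hold more compounds than are shown below. What is called first, only, known or untested is meant among the compounds shown, and "the series" means these compounds.

In an ADME assay on CCRF-CEM cells (Homo sapiens) for cytotoxicity, with a stated time of 3 days (a higher number here means that more compound is tolerated, a lower number that less compound is tolerated), compound 3 `O=C(OC1C=CC(n2ccc(=O)n(C(=O)c3ccccc3)c2=O)C1)c1ccccc1` gives >= 250000 nM, which is a limit and not a number. Compound 2 `Cc1cc(=O)n(C(=O)c2ccccc2)c(=O)n1C1C=CC(OC(=O)c2ccccc2)C1` gives a true number, 191000 nM, but its step to the other compound, an at least 1.3-fold higher number from compound 2 to compound 3 (0.11 log units; that floor lies within the scatter), concerns a different part of the molecule. Compound 4 `Cc1ccc(Cn2c(=O)ccn(C3C=CC(OC(=O)c4ccccc4)C3)c2=O)c(C)c1` brings (2,4-dimethylbenzyl in place of benzoyl on an aromatic nitrogen), so 2,4-dimethylbenzyl replaces benzoyl on an aromatic nitrogen. The nearest comparison is compound 1 `Cc1ccc(Cn2c(=O)ccn(C3C=CC(OC(=O)c4ccccc4)C3)c2=O)cc1`, which carries 4-methylbenzyl at that place. Compound 1 gives > 25000 nM, also a limit. The matching step, a step that the two limits leave unreadable from compound 1 to compound 3, therefore fixes no size. A fall is still expected, with the estimated change being an at least 6.2-fold lower number from compound 3 to compound 4 (0.79 log units; beyond the scatter). For compound 4 the estimate is 40000 nM, with an expected range from 10000 nM to 200000 nM.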

Compound 4, half-maximal cytotoxic concentration: 31000 nM
Compound 4: middle estimate off by 1.3-fold (0.11 log units), on the high side; the measured number falls inside the stated range.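

In this assay, 2,4-dimethylbenzyl in place of benzoyl on the aromatic nitrogen gives an at least 8.0-fold lower number from compound 3 to compound 4 (0.90 log units; beyond the scatter). That size is only a floor, because compound 3 rests on a limit: the limit of >= 250000 nM in this assay, at which 1 of the 4 values shown sits. Compound 1, with 4-methylbenzyl at this place, gives > 25000 nM, which is a limit, so its step to compound 4 cannot be read, and compound 4 holds the only true number among the benzyl groups shown.

The compounds shown leave open how a benzyl without methyl groups, or one carrying an amine or a carboxylic acid, would read at this nitrogen.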